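Swapping the nitro-bearing ring for a dihydroxyphenyl

The source may report more compounds than this note shows. Statements on the series, on what has been measured and on what is new or still open speak of the compounds shown alone.

Three compounds share a four-membered lactam core carrying a phenoxy group and a trimethoxyphenyl on the nitrogen, and differ only in the aryl group on a saturated ring carbon. Compound 1 `COc1ccc([C@@H]2[C@@H](Oc3ccccc3)C(=O)N2c2cc(OC)c(OC)c(OC)c2)cc1` gives 6900 nM in a functional assay on MCF7 cells (Homo sapiens) for antiproliferative activity, read by MTT assay, with stated times of 24 h and 72 h; a higher number here means a weaker inhibitor, a lower number a stronger inhibitor. Compound 2 `COc1cc(N2C(=O)[C@@H](Oc3ccccc3)[C@H]2c2ccc(Br)cc2)cc(OC)c1OC` gives 48000 nM in that assay, and compound 3 `COc1cc(N2C(=O)[C@@H](Oc3ccccc3)[C@H]2c2cccc([N+](=O)[O-])c2)cc(OC)c1OC` gives 30000 nM. Compound 3 therefore has the second highest of the three numbers: compound 2 lies within the scatter of it, while compound 1 is clearly lower, with a gap beyond the scatter.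

Compound 4 `COc1cc(N2C(=O)[C@@H](Oc3ccccc3)[C@H]2c2ccc(O)c(O)c2)cc(OC)c1OC` is the next member, and its change from compound 3 is 3,4-dihydroxyphenyl in place of 3-nitrophenyl on a saturated ring carbon.

Within the data shown here, only one measured step touches this position: a 1.6-fold lower number from compound 2 to compound 3 (0.20 log units; within the scatter), which did not move the number beyond the scatter. Among the measured compounds shown here, no measured step puts hydroxyl groups on this ring, so the data offer no direct guide. The one clear contrast, compound 1 against compound 3, shows that an oxygen-bearing aryl group can sit well below the nitro compound. A modest move toward lower numbers is therefore expected for compound 4, roughly a 2.0-fold lower number from compound 3 to compound 4 (0.30 log units; within the scatter). Compound 4 is estimated at 15000 nM, with a plausible range from 4000 nM to 60000 nM.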

Compound 4, half-maximal inhibitory concentration: 4500 nM
Estimate against measurement, compound 4: 3.3-fold (0.52 log units) above, and the stated range covers the measured number.
By their numbers in this assay, from the lowest: compounds 4 and 1 (each within the scatter of the next); then compounds 3 and 2 (each within the scatter of the next).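

The aryl group on this saturated ring carbon can clearly shift the number, as the change to 3,4-dihydroxyphenyl gives a 6.7-fold lower number from compound 3 to compound 4 (0.82 log units; beyond the scatter) and an 11-fold lower number from compound 2 to compound 4 (1.03 log units; beyond the scatter), whereas the earlier step between compound 2 and compound 3 stayed within the scatter. In this assay, compound 4 gives 4500 nM and compound 1 gives 6900 nM, values within the scatter of each other, so the two hydroxyl groups of compound 4 and the methoxy-bearing aryl group of compound 1 sit at the same level here, apart from both of the aryl groups in compound 2 and compound 3. No supporting measurement is available to explain why this swap matters.

The compounds shown leave open whether both hydroxyl groups are needed, since a phenyl ring with a single hydroxyl would separate the contribution of each one from that of the pair. They also leave open whether an amine or a carboxylic acid on this ring would keep the number at the level of compound 4 or return it toward that of compound 3.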